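The source may hold more compounds than are shown below. What is called first, only, known or untested is meant among the compounds shown, and "the series" means these compounds.

Compound 1 `CC(C)N(Cc1cccc(OCCCCCC(=O)O)c1)C(=O)c1ccc(-c2ccoc2)cc1` opens the series. In an ADME assay on Raji cells (Homo sapiens) for cytotoxicity, read by CellTiter-Glo and resazurin assay, with a stated time of 72 h (a lower number here means that less compound is needed, a higher number that more compound is needed for the effect), compound 1 gives a limit, > 26000 nM. Compound 2 `CC(C)Oc1cccc(-c2ccc(C(=O)N(Cc3cccc(OCCCCCC(=O)O)c3)C(C)C)cc2)c1` carries 3-isopropoxyphenyl in place of furan-3-yl on an aromatic carbon. In this assay compound 2 also gives a limit, > 26000 nM. The step that the two limits leave unreadable from compound 1 to compound 2 therefore has no readable size, and both values sit at the limit of > 26000 nM in this assay, at which 2 of the 2 values shown sit. Compound 3 `COc1cc(OC)cc(-c2ccc(C(=O)N(Cc3cccc(OCCCCCC(=O)O)c3)C(C)C)cc2)c1` differs from compound 2 by 3,5-dimethoxyphenyl in place of 3-isopropoxyphenyl on an aromatic carbon. Among the measured compounds shown here, the only measured step, from compound 1 to compound 2, touches the same aromatic carbon, but its size is hidden behind the two limits, so no step of known size bears on the change. Compound 2 stands at a limit in this assay, not at a number. With nothing pointing either way, compound 3 is expected to stay at the limit as well, estimated at 40000 nM, between 15000 nM and 120000 nM. The step this estimate implies is a step that the limit leaves unreadable from compound 2 to compound 3, expected to lie within the scatter.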

Compound 3, half-maximal effective concentration: > 26000 nM
Compound 3 gave a limit, no number (the forecaster's own chance of this, stated with the estimate: 85%); the middle value does not contradict the limit.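

No step can be read among compound 1, compound 2 and compound 3 in this assay, as all three values are limits: the limit of > 26000 nM in this assay, at which 3 of the 3 values shown sit.

On these data alone, how furan-3-yl, 3-isopropoxyphenyl and 3,5-dimethoxyphenyl compare on this aromatic carbon of the shared core stays open, as does whether any group there gives a measurable half-maximal effective concentration.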